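Chalcone aryl variation on the carbonyl side: biphenyl analogue

The source may hold more compounds than are shown below. What is called first, only, known or untested is meant among the compounds shown, and "the series" means these compounds.

Measured so far in a functional assay on HepG2 cells (Homo sapiens) for antiproliferative activity, read by MTT assay, with a stated time of 48 h; a lower number here means a stronger inhibitor, a higher number a weaker inhibitor:
compound 1 `CCOc1ccc(C(=O)/C=C/c2c(/C=C/c3ccc(OC)cc3)cc(OC)cc2OC)cc1`: 8 ug/mL
compound 2 `COc1ccc(/C=C/c2cc(OC)cc(OC)c2/C=C/C(=O)c2ccccc2C)cc1`: 5.3 ug/mL
compound 3 `COc1ccc(/C=C/c2cc(OC)cc(OC)c2/C=C/C(=O)c2ccc(C)c(C)c2)cc1`: 0.2 ug/mL

Compound 3 holds the lowest number of the three, and both of its neighbours lie beyond the scatter: a 40-fold lower number from compound 1 to compound 3 (1.60 log units; beyond the scatter) and a 27-fold lower number from compound 2 to compound 3 (1.42 log units; beyond the scatter). The step of a 1.5-fold lower number from compound 1 to compound 2 (0.18 log units; within the scatter), by contrast, is within the scatter, so only the 3,4-dimethylphenyl has so far moved the read-out clearly.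

Compound 4 `COc1ccc(/C=C/c2cc(OC)cc(OC)c2/C=C/C(=O)c2ccc(-c3ccccc3)cc2)cc1` differs from compound 3 in one place: 4-phenylphenyl in place of 3,4-dimethylphenyl on a carbonyl carbon. Among the measured compounds shown here, no measured step changes the group on the carbonyl carbon to anything of this size, so the bearing of the earlier steps is indirect. They show that the identity of the aryl group on the carbonyl carbon can shift the number strongly, and that compound 3 is the outlier among otherwise similar values. A step back toward the values of compound 1 and compound 2 is therefore the expectation, in the direction of a higher number. Compound 4 is estimated at 1.5 ug/mL, meaning an expected step of a 7.5-fold higher number from compound 3 to compound 4 (0.88 log units; beyond the scatter). For compound 4 the expected range runs from 0.3 ug/mL to 8 ug/mL.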

Compound 4, half-maximal inhibitory concentration: 10.5 ug/mL
Compound 4: middle estimate off by 7.0-fold (0.85 log units), on the low side; the measured number lies above the stated range.
By their numbers in this assay, from the lowest: compound 3; then compounds 2, 1 and 4 (each within the scatter of the next).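

In this assay, 4-phenylphenyl on the carbonyl carbon gives a 53-fold higher number from compound 3 to compound 4 (1.72 log units; beyond the scatter) and so does not keep the low number of the 3,4-dimethylphenyl, even though it too is a carbon-only aryl group without hydrogen-bond donors or acceptors. Set against the other two analogues, a 2.0-fold higher number from compound 2 to compound 4 (0.30 log units; within the scatter) and a 1.3-fold higher number from compound 1 to compound 4 (0.12 log units; within the scatter) leave 2-methylphenyl, 4-ethoxyphenyl and 4-phenylphenyl unresolved from one another, which makes compound 3 the only clear departure among the four compounds. No measurement to hand accounts for what sets the 3,4-dimethylphenyl apart.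

Open, from the compounds shown here alone, is whether a phenyl ring carrying a single methyl group would keep any of the low number of compound 3. Also open, going by these compounds, is how a chlorophenyl or pyridyl group on the carbonyl carbon would read in this assay.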